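Chloro for methyl on a purine-benzamide hybrid

The source may hold more compounds than are shown below. What is called first, only, known or untested is meant among the compounds shown, and "the series" means these compounds.

Measured so far:
compound 1, `Cc1ccc(Nc2nc(Cl)nc3c2ncn3Cc2ccc(C(=O)Nc3ccccc3N)cc2)cc1`, 81.5%
compound 2, `Nc1ccccc1NC(=O)/C=C/c1ccc(COCNc2nc(Nc3cccc(Cl)c3)c3ncn(C4CCCC4)c3n2)cc1`, 9.19%
compound 3, `Nc1ccccc1NC(=O)/C=C/c1ccc(Cn2cnc3c(Nc4cccc(OC(F)(F)F)c4)nc(Cl)nc32)cc1`, 5.23%

In a functional assay on HCT-116 cells (Homo sapiens) for antiproliferative activity, read by CCK-8 assay, with a stated time of 72 h, tested at 8 uM (a lower number here means a weaker effect, a higher number a stronger effect of the compound at the concentration tested), compound 1 gives the highest of the three numbers. Compound 2 sits well below it, a gap beyond the scatter, and compound 3 sits lower still. Both weaker compounds carry a longer linker between the shared core and the amide, which compound 1 does not.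

Compound 4, `Nc1ccccc1NC(=O)c1ccc(Cn2cnc3c(Nc4cccc(Cl)c4)nc(Cl)nc32)cc1`, keeps the short linker of compound 1 and changes only the aryl group on the ring nitrogen: 3-chlorophenyl in place of 4-methylphenyl on a nitrogen on an aromatic ring. For the measured compounds named here, since compound 1 is the only close neighbour, the expected step of a number 11.5 percentage points lower from compound 1 to compound 4 (beyond the scatter) is a modest drop, though it could also fall within the scatter. Compound 4 is therefore estimated at 70%, with a range from 40% to 90%.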

Compound 4, a percentage reported as inhibition, at one concentration (the size of the read-out at that concentration, not a potency): 78.4%
The estimate for compound 4 lay 8.4 percentage points below the measured number; the measured number falls inside the stated range.
By their numbers in this assay, from the lowest: compounds 3 and 2 (each within the scatter of the next); then compounds 4 and 1 (each within the scatter of the next).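

With 3-chlorophenyl in place of 4-methylphenyl on a nitrogen on an aromatic ring, the read-out in this assay is a number 3.1 percentage points lower from compound 1 to compound 4 (within the scatter). This first comparison of compounds differing in one place shows that, on this core with its short linker, these two aryl groups cannot be told apart. Nothing measured here explains why they read alike.

From the compounds shown here alone, it remains open whether this position also accepts a phenyl ring carrying an amine or a carboxylic acid, or a saturated ring such as cyclohexyl. Going by these compounds, the separate role of the longer linker also remains open.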